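Replacing an Amino Group with a Methyl Ester

This account rests on a few compounds, and the source may have more. Where it says the series, first, only, none or still open, it means among the compounds named here.

Three compounds share one core and differ only in the group carried by the outer ring. Compound 1 `COc1cc2ncnc(Nc3ccc(B(O)O)cc3)c2cc1OC` gives 49% in an assay on isolated protein for inhibition of vascular endothelial growth factor receptor 1 (Homo sapiens), read by ELISA, with a stated time of 20 min, tested at 1 uM; a lower number here means less inhibition, a higher number more inhibition at the concentration tested (going by the name of the read-out). Compound 2 `COc1cc2ncnc(Nc3ccc(N)cc3)c2cc1OC`, which carries an amino group at that position, is reported in this assay as "not active" (no number reported), so no number stands against it: it shows no measurable inhibition, and its place on the scale is simply at the bottom. Compound 3 `COC(=O)c1ccc(Nc2ncnc3cc(OC)c(OC)cc23)cc1` has not been measured yet. The change from compound 2 to compound 3 is methoxycarbonyl in place of amino on an aromatic carbon. Among the compounds with values here, with no measured step of this kind to lean on, the expectation for this assay is a modest number, likely not beyond the usual scatter from the bottom of the scale where compound 2, reported as not active, stands, and clearly below what compound 1 gives. Compound 3 is therefore expected to give about 15%, somewhere between 0% and 40%.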

Compound 3, a percentage reported as inhibition, at one concentration (the size of the read-out at that concentration, not a potency): "not active" (no number reported)
For compound 3 the study gives words and no number; there is nothing to compare the estimate with.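

In this assay compound 2 and compound 3 are both reported in words without a number, so no step can be read between them. The compounds shown leave open whether amino and methoxycarbonyl differ at all in this inhibition, and no other measurement bears on that result.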